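The source may report more compounds than this note shows. Statements on the series, on what has been measured and on what is new or still open speak of the compounds shown alone.

Two compounds have been measured in an assay on RBL-1 cells for inhibition of Polyunsaturated fatty acid 5-lipoxygenase (Rattus norvegicus); on this read-out higher numbers stand for weaker inhibition and lower numbers for stronger inhibition:

Compound 1 `O=C(/C=C/c1ccc(O)c(O)c1)c1cccc(O)c1` gives 4.2 nM
Compound 2 `O=C(/C=C/c1ccc(O)c(O)c1)c1c(O)cc(O)cc1O` gives 140 nM

Both share the same core, a catechol-bearing chalcone, and differ only in how the ketone-side ring is decorated. Compound 1 carries a single hydroxy group there and has the lowest number of the two; compound 2 carries three hydroxy groups and sits at a higher number, a gap that lies beyond the usual scatter of this assay. Nothing more can be drawn from this pair, since the two structures differ in more than one place.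

Compound 3 `CN(C)c1cccc(C(=O)/C=C/c2ccc(O)c(O)c2)c1` has not yet been measured. Compared with compound 1, the change is dimethylamino in place of hydroxy on an aromatic carbon. For the measured compounds named here, no measured pair shows this exact change, so the expectation rests on compound 1 alone. The step from compound 1 to compound 3 is expected to be a 3.6-fold higher number from compound 1 to compound 3 (0.55 log units; beyond the scatter), a modest rise in number, possibly within the scatter. Compound 3 is thus expected to give about 15 nM, with a plausible range from 3 nM to 80 nM.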

Compound 3, half-maximal inhibitory concentration: 9.8 nM
The estimate for compound 3 lay 1.5-fold (0.18 log units) above the measured number; the measured number falls inside the stated range.
By their numbers in this assay, from the lowest: compound 1; then compound 3; then compound 2.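

In this assay, replacing the hydroxy of compound 1 with dimethylamino, on an aromatic carbon meta to a large group, gives a 2.3-fold higher number from compound 1 to compound 3 (0.37 log units; beyond the scatter). For the compounds shown here, this is the first measured change at this position, and it shows that a larger group with no hydrogen-bond donor can stand there while inhibition weakens only modestly, with compound 3 still at 9.8 nM. No independent measurement is available to explain why the number rises, so the step records an outcome and not a mechanism.

The single swap changes the size of the group and removes the hydrogen-bond donor together, so the compounds shown cannot tell which of these differences matters, or whether both do. A methoxy group, a primary amine or a plain hydrogen at the same position could help pull these differences apart, while a carboxylic acid or a longer chain there would test how much further the position can be changed.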